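A few compounds are considered here, and "the series" means these few. Any claim that something is new, unique, unknown or untested is made for them only; others in the source may bear on it.

Compound 1, `O=[N+]([O-])c1ccc(CN2CCC(n3cc(CC(OCc4cc(-c5cccc(F)c5)no4)c4ccc(Br)cc4)nn3)CC2)cc1`, gives in an ADME assay on cells (Fibroblast, Homo sapiens) for cytotoxicity, with a stated time of 48 h (on this read-out higher numbers stand for weaker inhibition and lower numbers for stronger inhibition), a reading of 10000 nM. Compound 2, `N#Cc1cccc(-c2cc(COC(Cc3cn(C4CCN(Cc5ccc([N+](=O)[O-])cc5)CC4)nn3)c3ccc(Br)cc3)on2)c1`, differs from it only by a cyano group in place of a fluoro group on an aromatic carbon. For compound 2 the assay reports only a limit, > 25000 nM, and not a number. That change produced an at least 2.5-fold higher number from compound 1 to compound 2 (0.39 log units; beyond the scatter), so compound 2 stands at the weak end of what has been measured, at the limit of > 25000 nM in this assay, at which 1 of the 2 values shown sits.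

Compound 3, `COc1ccccc1-c1cc(COC(Cc2cn(C3CCN(Cc4ccc([N+](=O)[O-])cc4)CC3)nn2)c2ccc(Br)cc2)on1`, carries a further change at the same aromatic carbon: 2-methoxyphenyl in place of 3-cyanophenyl on an aromatic carbon. Among the measured compounds shown here, the only measured step, from compound 1 to compound 2, concerns a different pair of groups and bears on this one only loosely. Cytotoxicity is expected to stay weak, and the step of an at least 1.2-fold lower number from compound 2 to compound 3 (0.09 log units; that floor lies within the scatter) is expected to lie within the scatter. Compound 3 is therefore estimated at 20000 nM, with a range from 8000 nM to 50000 nM.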

Compound 3, half-maximal inhibitory concentration: > 25000 nM
Compound 3: only a limit was reported; the forecaster's own chance of this, stated with the estimate: 50%; middle value at least 1.2-fold (0.09 log units) away from the limit.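

In this assay, 2-methoxyphenyl in place of 3-fluorophenyl on this aromatic carbon gives an at least 2.5-fold higher number from compound 1 to compound 3 (0.39 log units; beyond the scatter). Two different replacements of 3-fluorophenyl, 3-cyanophenyl in compound 2 and 2-methoxyphenyl in compound 3, now both give weaker cytotoxicity than compound 1, so the shift is not tied to the cyano group alone. The step from compound 2 to compound 3 cannot be read, because both readings are limits and not numbers: the limit of > 25000 nM in this assay, at which 2 of the 3 values shown sit.

Which of compound 2 and compound 3 is the weaker stays unknown, as does whether removing the fluoro group is enough for the shift. Also open, from the compounds shown here alone, is how an unsubstituted phenyl, or a phenyl carrying an amine or a carboxylic acid, would read at this position.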